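Aryl Groups in Place of Bromine on a Fused Core

A few compounds are considered here, and "the series" means these few. Any claim that something is new, unique, unknown or untested is made for them only; others in the source may bear on it.

Compound 1 `Brc1cn2ccnc2c(-c2ccc3ncn(C4CCCCC4)c3c2)n1` gives 10% in a functional assay on SF-539 cells (Homo sapiens) for inhibition, read by sulforhodamine B assay, with a stated time of 48 h, tested at 10 uM (a higher number here means more inhibition at the concentration tested (going by the name of the read-out), a lower number less inhibition), the second highest of three numbers measured: compound 2 `CC(=O)c1ccc(-c2cn3ccnc3c(-c3ccc4ncn(C5CCCCC5)c4c3)n2)cc1` gives 2.82% and compound 3 `Brc1ccc(-c2cn3ccnc3c(-c3ccc4ncn(C5CCCCC5)c4c3)n2)cc1` gives 24.4%. The step of a number 7.2 percentage points lower from compound 1 to compound 2 (within the scatter) stays within the scatter, while the step of a number 14.4 percentage points higher from compound 1 to compound 3 (beyond the scatter) lies beyond it. Compound 4 `COc1ccccc1-c1cn2ccnc2c(-c2ccc3ncn(C4CCCCC4)c3c2)n1` is the next member of this set: 2-methoxyphenyl in place of bromo on an aromatic carbon. Both measured steps from compound 1 bear on this change, one flat and one modestly upward, so a small upward step, or none beyond the scatter, is what is expected for the step of a number 5 percentage points higher from compound 1 to compound 4 (within the scatter). Compound 4 is therefore estimated at 15% in this assay, within a range of 0% to 35%.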

Compound 4, a percentage reported as inhibition, at one concentration (the size of the read-out at that concentration, not a potency): 8.07%
For compound 4 the middle estimate is 6.9 percentage points above the measured one, and the stated range covers the measured number.
By their numbers in this assay, from the lowest: compounds 2, 4 and 1 (each within the scatter of the next); then compound 3.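

The step of a number 1.9 percentage points lower from compound 1 to compound 4 (within the scatter) shows that 2-methoxyphenyl, like 4-acetylphenyl, does not separate from bromo at this position in this assay, while the step of a number 5.3 percentage points higher from compound 2 to compound 4 (within the scatter) leaves those two aryl groups unseparated as well. Aryl substitution alone therefore does not raise the number, and compound 3 goes against this flat result, as the step of a number 16.3 percentage points lower from compound 3 to compound 4 (beyond the scatter) shows. Nothing available explains why compound 3 stands apart. The compounds shown leave open whether that higher number depends on the bromine of the 4-bromophenyl group, and whether an amine or a carboxylic acid in its place would retain it.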